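Working notes on a nitrophenyl hydrazone series, compound 4 pending

This account rests on a few compounds, and the source may have more. Where it says the series, first, only, none or still open, it means among the compounds named here.

Values in a functional assay on cells (Splenocyte, Mus musculus, strain BALB/c) for inhibition, read by scintillation counting and thymidine incorporation, with a stated time of 72 h; on this read-out lower numbers stand for stronger inhibition and higher numbers for weaker inhibition:
compound 1 `CC(/C=N/Nc1ccc([N+](=O)[O-])cc1)=N\NC(=O)c1ccccc1Cl`: > 12000 nM
compound 2 `CC(/C=N/Nc1ccc([N+](=O)[O-])cc1)=N\NC(=O)c1ccccc1Nc1ccccc1`: "not determined" (no result reported)
compound 3 `CC(/C=N/Nc1ccc([N+](=O)[O-])cc1)=N\NC(=O)c1ccccc1N`: 4900 nM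

Within the data shown here, compound 3 is the only member of the series with a number in this assay. For compound 1 the value is a limit of the assay, not a number (the limit of > 12000 nM in this assay, at which 1 of the 3 values shown sits). Compound 2 has no result. Among the measured compounds shown here, the one measured step, an at least 2.4-fold lower number from compound 1 to compound 3 (0.38 log units; beyond the scatter), shows that exchanging chloro for amino at the same aromatic carbon lowers the number at least modestly, beyond the scatter.

Compound 4 `CC(/C=N/Nc1ccc([N+](=O)[O-])cc1)=N\NC(=O)c1ccc(Cl)cc1` differs from compound 3 by 4-chlorophenyl in place of 2-aminophenyl on a carbonyl carbon. This reverses the donor-bearing amino of compound 3 to a chloro, though at a different carbon of the ring, so the step from compound 1 to compound 3 bears on it only in part. On that basis the number for compound 4 is expected to rise in this assay, with a step estimated at a 3.1-fold higher number from compound 3 to compound 4 (0.49 log units; beyond the scatter), and a real chance that only a limit is returned. The estimate for compound 4 is 15000 nM, within 5000 nM to 40000 nM.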

Compound 4, half-maximal inhibitory concentration: 4200 nM
For compound 4 the middle estimate is 3.6-fold (0.55 log units) above the measured one; the measured number lies below the stated range.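

In this assay, replacing 2-aminophenyl with 4-chlorophenyl on the carbonyl carbon gives a 1.2-fold lower number from compound 3 to compound 4 (0.07 log units; within the scatter), so compound 3 and compound 4 cannot be told apart and a ring substituent with a hydrogen-bond donor is not needed to give a measurable number. A chloro on the ring does not by itself push the read-out to the limit, as moving from 2-chlorophenyl to 4-chlorophenyl gives an at least 2.8-fold lower number from compound 1 to compound 4 (0.45 log units; beyond the scatter), which makes the place of the chloro matter in this pair. For compound 1 the reading is a limit, not a number: the limit of > 12000 nM in this assay, at which 1 of the 4 values shown sits.

Compound 2 has no result, so its step cannot be read. From the compounds shown here alone, whether a methoxy group or a carboxylic acid on this ring would match compound 3 and compound 4 remains open.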